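Swapping the Bicyclic Amide Group in a Sulfonyl Series

This account rests on a few compounds, and the source may have more. Where it says the series, first, only, none or still open, it means among the compounds named here.

Measured so far:
compound 1 `O=C(NCc1ccc(S(=O)(=O)c2ccccc2)cc1)c1cc2ncccc2s1`: 1.6%
compound 2 `O=C(NCc1ccc(S(=O)(=O)N2CCCCC2)cc1)c1cc2cnccc2s1`: see below
compound 3 `CC(NC(=O)c1cc2cnccc2[nH]1)c1ccc(S(=O)(=O)N2CCCCC2)cc1`: 0.65%

In an ADME assay on microsomes from liver (Mus musculus) for metabolic stability, read by LC-MS, with a stated time of 30 min, tested at 1 uM (a higher number here means that more of the compound is left, a lower number that less of the compound is left), compound 1 gives 1.6%, the higher of the two numbers reported. Compound 3 gives 0.65% in this assay, a value within the usual scatter of that of compound 1, so the two cannot be told apart. For compound 2 the result in this assay is reported only as "below limit of detection" (no number reported), without a number.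

Compound 4 `O=C(NCc1ccc(S(=O)(=O)c2ccccc2)cc1)c1cn2ccnc2cn1` has not been measured. It differs from compound 1 in one place: a group of 9 heavy atoms (6 carbon, 3 nitrogen; one five-membered aromatic ring with 2 hetero atoms, one six-membered aromatic ring with 2 hetero atoms) in place of a group of 9 heavy atoms (7 carbon, 1 nitrogen, 1 sulfur; one five-membered aromatic ring with 1 hetero atom, one six-membered aromatic ring with 1 hetero atom), on a carbonyl carbon

Going by the values given here, no measured pair shows what this kind of change does. Since every number in this assay sits very low, there is little room downward, and the step from compound 1 to compound 4 is expected to be small, a number 2.4 percentage points higher from compound 1 to compound 4 (within the scatter), most likely within the scatter. Compound 4 is therefore estimated at 4%, with a range from 0.5% to 15%.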

Compound 4, percent of the compound remaining: 13%
The estimate for compound 4 lay 9 percentage points below the measured number; the measured number falls inside the stated range.
By their numbers in this assay, from the lowest: compounds 3 and 1 (each within the scatter of the next); then compound 4.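

Swapping the group on the carbonyl carbon, with the rest of compound 1 unchanged, gives a number 11.4 percentage points higher from compound 1 to compound 4 (beyond the scatter) in this assay, the first step in this set that can be read across a single change and the first to show that this position can affect how much compound is left. Even so, compound 4 at 13% still keeps only a small part of the compound. No supporting measurement explains this step.

The entering group differs from the one it replaces in both its ring atoms and its acceptor count, and this single pair cannot show which difference matters. It also leaves open whether the same swap would give a similar step with the other sulfonyl groups in the set, or whether a methyl group or fluorine atom on the entering group would change the number further.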